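An aryl swap on the amide of compound 2

This account rests on a few compounds, and the source may have more. Where it says the series, first, only, none or still open, it means among the compounds named here.

Among the compounds with values here, compound 2 `COc1ccccc1NC(=O)CCC(=O)OCCCCCCSc1ccc([N+](=O)[O-])c2nonc12` gives 4050 nM in an assay on isolated protein for inhibition of glutathione S-transferase P (Homo sapiens), with a stated time of 10 min (a higher number here means a weaker inhibitor, a lower number a stronger inhibitor), the highest of the two numbers known; compound 1 `O=C(O)CCC(=O)OCCCCCCSc1ccc([N+](=O)[O-])c2nonc12` gives 530 nM. Within the data shown here, the single measured step, a 7.6-fold higher number from compound 1 to compound 2 (0.88 log units; beyond the scatter), concerns the amide itself rather than the aryl group on it. Compound 3 `O=C(CCC(=O)OCCCCCCSc1ccc([N+](=O)[O-])c2nonc12)Nc1cccc(Cl)c1` carries 3-chlorophenyl in place of 2-methoxyphenyl on an amide-type nitrogen. Among the measured compounds shown here, no measured step touches an aryl exchange on the amide nitrogen, so nothing beyond the scatter is expected, and the expected step is a 1.0-fold lower number from compound 2 to compound 3 (0.01 log units; within the scatter). Compound 3 is therefore estimated at 4000 nM, with a range from 1500 nM to 11000 nM.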

Compound 3, half-maximal inhibitory concentration: 28800 nM
Compound 3: the middle estimate sits 7.2-fold (0.86 log units) below what was measured; the measured number lies above the stated range.
By their numbers in this assay, from the lowest: compound 1; then compound 2; then compound 3.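

In this assay, the aryl group on the amide-type nitrogen proves not to be a neutral part of the molecule: 3-chlorophenyl in place of 2-methoxyphenyl gives a 7.1-fold higher number from compound 2 to compound 3 (0.85 log units; beyond the scatter), so the cost of the amide depends on its aryl group. Measured from the free acid, (3-chlorophenyl)amino in place of hydroxy gives a 54-fold higher number from compound 1 to compound 3 (1.74 log units; beyond the scatter). Nothing available explains this change. The substituent and the place it occupies on the ring change together here, so their shares remain unseparated. On these data alone, how a plain phenyl group on that nitrogen would compare remains open.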